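From methoxy to hydroxy on the double-bonded nitrogen

The compounds below may be only part of what the source reports. "The series", "measured", "known", "first", "only" and "open" are said of these compounds alone.

Measured in a functional assay on the whole organism with Rattus norvegicus as the target; a higher number here means that more compound is needed for the effect, a lower number that less compound is needed:
- Compound 1 `Nc1nc2ccc(I)cc2s1`: > 10 mg/kg (a limit)
- Compound 2 `CCSCCn1/c(=N/C)sc2cc(OC(F)(F)F)ccc21`: 3.7 mg/kg
- Compound 3 `CCSCCn1/c(=N/OC)sc2cc(OC(F)(F)F)ccc21`: > 10 mg/kg (a limit)

Compound 3 stands at the limit of > 10 mg/kg in this assay, at which 2 of the 3 values shown sit. Its true value is therefore unknown.

Compound 4 `CCSCCn1/c(=N/O)sc2cc(OC(F)(F)F)ccc21` has hydrogen in place of methyl on an oxygen, so methoxy becomes hydroxy (hydrogen in place of methyl on an oxygen). Among the compounds with values here, no measured step makes this exact change. The nearest evidence is an at least 2.7-fold higher number from compound 2 to compound 3 (0.43 log units; beyond the scatter), with methoxy in place of methyl on a double-bonded nitrogen. That step was beyond the scatter, and it shows that the group at this place can matter in this assay. Removing the methyl does not reverse that step, however, so it gives only weak guidance on direction and size.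

A modest move toward a lower number is expected, with an estimated at least 1.4-fold lower number from compound 3 to compound 4 (0.15 log units; that floor lies within the scatter). Compound 4 could also remain at the limit. For compound 4, the expected value is 7 mg/kg, with an estimated range of 2.5 mg/kg to 20 mg/kg.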

Compound 4, dose for half-maximal effect: > 10 mg/kg
Compound 4 gave a limit, no number; the forecaster's own chance of this, stated with the estimate: 45%; at least 1.4-fold (0.15 log units) between middle value and limit.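

In this assay, hydroxy in place of methyl on the double-bonded nitrogen gives an at least 2.7-fold higher number from compound 2 to compound 4 (0.43 log units; beyond the scatter). Both groups tried there that join the nitrogen through oxygen, methoxy and hydroxy, now stand apart from methyl, so the shift seen with compound 3 does not depend on the methyl of methoxy. The step from compound 3 to compound 4 cannot be read, because both values are limits: the limit of > 10 mg/kg in this assay, at which 3 of the 4 values shown sit.

Going by these compounds, how far compound 3 and compound 4 lie past that limit remains open, and so does whether they differ at all. Also open, on these data alone, is whether an amino group or an ethyl group on the double-bonded nitrogen would read like compound 2 or like the two compounds at the limit in this assay.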